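This account rests on a few compounds, and the source may have more. Where it says the series, first, only, none or still open, it means among the compounds named here.

Two compounds have so far been measured in a functional assay on aorta (Rattus norvegicus, strain Sprague-Dawley); on this read-out lower numbers stand for smaller maximal responses and higher numbers for larger maximal responses:
compound 1 `CC(C)=CCc1c(O)cc(O)c(C(=O)/C=C/c2ccc(Cl)cc2)c1O`, 64.4%
compound 2 `CC(C)=CCc1c(O)cc(O)c2c(=O)cc(-c3cccc(Br)c3)oc12`, 82.8%

Compound 2 stands highest of the two numbers. Its nearest neighbour is compound 1, whose value lies lower by a margin that goes beyond the usual scatter of this assay. Among the measured compounds shown here, the two compounds differ from each other in more than one place, so no single step between measured compounds can be read from them; only their two values stand side by side.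

Compound 3 `CC(C)=CCc1c(O)cc(O)c2c(=O)cc(-c3cccc(O)c3)oc12` has not yet been measured. It arises from compound 2 by one change: hydroxy in place of bromo on an aromatic carbon. For the measured compounds named here, no measured step of this kind is at hand, so the size of the move in this assay can only be expected, not derived. Compound 3 is expected to sit near compound 2, with a step of a number 7.8 percentage points lower from compound 2 to compound 3 (within the scatter) that is small and downward, most likely within the scatter. For compound 3 the estimate in this assay is 75%, with a range from 55% to 92%.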

Compound 3, largest response reached (Emax), in percent of the reference or control that the assay uses: 64.6%
Compound 3: middle estimate off by 10.4 percentage points, on the high side, within the range that was stated.
By their numbers in this assay, from the lowest: compounds 1 and 3 (each within the scatter of the next); then compound 2.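

Among the compounds shown here, the exchange of 3-bromophenyl for 3-hydroxyphenyl provides the first step in this assay that can be read between two compounds differing in one place, and it gives a number 18.2 percentage points lower from compound 2 to compound 3 (beyond the scatter). It shows that the response in this assay is sensitive to the group on this aromatic carbon, meta to a large group: a change of one heavy atom for one heavy atom, with a hydrogen-bond donor and a hydrogen-bond acceptor entering, is enough to carry the value beyond the scatter, and in the downward direction. Nothing at hand accounts for this drop, so the step stands as an observation without an explanation.

Open remains how an amine, a methoxy group or a carboxylic acid on this same carbon would stand in this assay against bromo and hydroxy, and so whether the step from bromo to hydroxy belongs to a wider trend or is particular to this pair. Also open, as far as these compounds go, is whether the same exchange would move the value in the same direction and by a similar amount on the core of compound 1, which carries a chloro group instead.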